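A Methyl Added Where Activity Was Lost

The source may report more compounds than this note shows. Statements on the series, on what has been measured and on what is new or still open speak of the compounds shown alone.

Of the compounds shown here, two have been measured in a functional assay on HeLa cells (Homo sapiens) for cytotoxicity, read by CCK-8 assay, with a stated time of 24 h; a lower number here means a stronger inhibitor, a higher number a weaker inhibitor. Compound 1, with the structure `C/C(=C\c1cc(-c2ccccc2)co1)C(N)=O`, gives a half-maximal inhibitory concentration of 3280 nM in this assay. Compound 2, with the structure `C/C(=C\c1cc(-c2cccnc2)co1)C(N)=O`, is reported in this assay only as a limit of > 50000 nM, so no number is known for it. This is where compound 2 stands: at the limit of > 50000 nM in this assay, at which 1 of the 2 values shown sits, which means its true value is not known beyond the statement that it lies past the range the assay can report.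

Compound 3, with the structure `C/C(=C\c1cc(-c2ccc(C)nc2)co1)C(N)=O`, has not yet been measured in this assay. It differs from compound 2 by a single change: methyl in place of hydrogen on an aromatic carbon. Among the compounds with values here, no measured pair in this set shows what such a change does, so the size of the step from compound 2 to compound 3 cannot be read from data here. Starting from a limit, the step is expected to stay within the scatter, as a step that the limit leaves unreadable from compound 2 to compound 3. For compound 3 the estimate in this assay is 60000 nM, with a range from 15000 nM to 200000 nM, most likely again reported only as a limit.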

Compound 3, half-maximal inhibitory concentration: > 50000 nM
Compound 3: no number, only a limit; the forecaster's own chance of this, stated with the estimate: 70%; the middle value does not contradict the limit.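

Within the data shown here, compound 2 and compound 3 are both reported in this assay only as limits, not as numbers, so no step between them can be read: the limit of > 50000 nM in this assay, at which 2 of the 3 values shown sit. The compounds shown leave open what the true values of compound 2 and compound 3 are, and whether methyl in place of hydrogen on an aromatic carbon changes activity at all.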